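Amino substitution on the benzoyl ring of compound 1

The source may report more compounds than this note shows. Statements on the series, on what has been measured and on what is new or still open speak of the compounds shown alone.

Compound 1 `O=C(/C=C/c1ccc2c(c1)B(O)OC2)c1ccccc1` is the unsubstituted member of this small set. Among the measured compounds shown here, in a functional assay on HCT-116 cells (Homo sapiens) for cytotoxicity, read by MTT assay, with a stated time of 48 h (a lower number here means a stronger inhibitor, a higher number a weaker inhibitor), compound 1 gives 6100 nM, the second highest of the three numbers measured so far. Compound 2 `O=C(/C=C/c1ccc2c(c1)B(O)OC2)c1ccc(F)cc1` gives 2800 nM, and compound 3 `Cc1ccc(C(=O)/C=C/c2ccc3c(c2)B(O)OC3)cc1` gives 10500 nM. Of the steps that start from compound 1, a 2.2-fold lower number from compound 1 to compound 2 (0.34 log units; beyond the scatter), whereas a 1.7-fold higher number from compound 1 to compound 3 (0.24 log units; within the scatter). Between the two substituted compounds, a 3.8-fold higher number from compound 2 to compound 3 (0.57 log units; beyond the scatter).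

Compound 4 `Nc1cccc(C(=O)/C=C/c2ccc3c(c2)B(O)OC3)c1` differs from compound 1 by amino in place of hydrogen on an aromatic carbon. Neither measured step places an amino group on this ring, and neither sits meta to a large group, so the two steps can only indicate the size of change that a single small substituent on this ring has produced: one modest, one within the scatter. As far as these compounds go, no step beyond the scatter is therefore expected in this assay from compound 1 to compound 4, and the direction remains open, since compound 2 and compound 3 moved opposite ways. The estimate for compound 4 is 5500 nM, with a range from 2200 nM to 14000 nM, which is an expected 1.1-fold lower number from compound 1 to compound 4 (0.04 log units; within the scatter).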

Compound 4, half-maximal inhibitory concentration: 4500 nM
Beside the measured number, compound 4's estimate is 1.2-fold (0.09 log units) above it, and the stated range covers the measured number.
By their numbers in this assay, from the lowest: compounds 2, 4, 1 and 3 (each within the scatter of the next, the first and the last beyond it).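

In this assay, amino in place of hydrogen on an aromatic carbon, meta to a large group, puts a hydrogen-bond donor on this ring for the only time in the set, and a 1.4-fold lower number from compound 1 to compound 4 (0.13 log units; within the scatter) shows that this change stays within the scatter of the unsubstituted compound. Against the other two substituted compounds the result splits: a 1.6-fold higher number from compound 2 to compound 4 (0.21 log units; within the scatter), whereas a 2.3-fold lower number from compound 3 to compound 4 (0.37 log units; beyond the scatter), so 3-aminophenyl cannot be told apart from 4-fluorophenyl here but does separate from 4-methylphenyl. No supporting measurement bears on why these steps have the sizes they do.

As far as these compounds go, the comparisons with compound 2 and compound 3 change both the group and its place on the ring, so it remains open whether amino would read the same where the fluoro and methyl groups sit. Also open, from the compounds shown here alone, is how this place on the ring would respond to a group larger than amino or different in kind, such as an acetamide or a carboxylic acid.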